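A few compounds are considered here, and "the series" means these few. Any claim that something is new, unique, unknown or untested is made for them only; others in the source may bear on it.

Of the compounds shown here, three have been measured in an assay on isolated protein for inhibition of Intestinal-type alkaline phosphatase (Bos taurus), read by spectrophotometry, with stated times of 7 min and 15 min; on this read-out lower numbers stand for stronger inhibition and higher numbers for weaker inhibition. Compound 1 `COc1ccc(Cn2c(-c3ccc(C)cc3)c(Br)c(=O)c3cc([N+](=O)[O-])ccc32)cc1` gives 2430 nM, and compound 2 `Cc1ccc(-c2c(Br)c(=O)c3cc([N+](=O)[O-])ccc3n2C(C)c2ccccc2)cc1` gives 2470 nM; the two cannot be told apart, as the step of a 1.0-fold higher number from compound 1 to compound 2 (0.01 log units; within the scatter) shows. Compound 3 `CCCCCc1c(Br)c(=O)c2cc([N+](=O)[O-])ccc2n1Cc1ccc(OC)cc1` gives 122000 nM, so compound 1 sits at the strong end of the three numbers, far from compound 3 and side by side with compound 2.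

Compound 4 `CCc1ccc(-c2c(-c3ccc(C)cc3)n(Cc3ccc(OC)cc3)c3ccc([N+](=O)[O-])cc3c2=O)cc1` has not yet been measured. It differs from compound 1 in one place: 4-ethylphenyl in place of bromo on an aromatic carbon. Going by the values given here, no measured step touches this position. The step of a 1.0-fold higher number from compound 1 to compound 2 (0.01 log units; within the scatter) concerns the group on the ring nitrogen and changed nothing beyond the scatter. The step of a 50-fold higher number from compound 1 to compound 3 (1.70 log units; beyond the scatter) concerns a group on an aromatic carbon of the same core and was large, which suggests that this part of the core is sensitive to what is attached there. Replacing bromo with 4-ethylphenyl is a bigger change than either measured step, so a weakening beyond the scatter is expected, but with wide uncertainty. Compound 4 is therefore expected to give about 6000 nM in this assay, somewhere between 1200 nM and 30000 nM, an estimated step of a 2.5-fold higher number from compound 1 to compound 4 (0.39 log units; beyond the scatter).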

Compound 4, half-maximal inhibitory concentration: 5750 nM
For compound 4 the middle estimate is 1.0-fold (0.02 log units) above the measured one; measured number inside the range.
By their numbers in this assay, from the lowest: compounds 1 and 2 (each within the scatter of the next); then compound 4; then compound 3.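

Replacing bromo with 4-ethylphenyl puts 8 heavy atoms and a six-membered aromatic ring where 1 heavy atom stood, yet this assay shows only a 2.4-fold higher number from compound 1 to compound 4 (0.37 log units; beyond the scatter). This position on the shared core can therefore carry a much larger group while inhibition is still read in the same assay, with a modest weakening rather than a large loss. With a single change here, the data cannot separate the loss of bromo from the arrival of the new ring, and no supporting measurement accounts for the shift.

Still open, from the compounds shown here alone, is how a plain hydrogen or a small methyl at this position would compare with bromo. Also open, going by these compounds, is whether an amine or a carboxylic acid on the added phenyl ring would move the number in either direction.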